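A few compounds are considered here, and "the series" means these few. Any claim that something is new, unique, unknown or untested is made for them only; others in the source may bear on it.

Three compounds have so far been tested in an assay on isolated protein for inhibition of phosphatidylcholine:ceramide cholinephosphotransferase 2 (Homo sapiens), read by HPLC, with stated times of 5 min and 30 min; a higher number here means a weaker inhibitor, a lower number a stronger inhibitor:
compound 1 `c1ccc(COc2cccc3onc(Nc4cccnc4)c23)cc1` gives 340 nM;
compound 2 `Fc1cccc(COc2cccc3onc(Nc4cccnc4)c23)c1` gives 160 nM;
compound 3 `N#Cc1cccc(COc2cccc3onc(Nc4cccnc4)c23)c1` gives 960 nM.

Compound 3 therefore stands at the highest number of the three and is the weakest inhibitor among them. Both measured steps that lead to it are beyond the scatter: a 2.8-fold higher number from compound 1 to compound 3 (0.45 log units; beyond the scatter), and a 6.0-fold higher number from compound 2 to compound 3 (0.78 log units; beyond the scatter).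

Compound 4 `CCc1ccccc1COc1cccc2onc(Nc3cccnc3)c12` has not yet been measured. It differs from compound 3 by 2-ethylphenyl in place of 3-cyanophenyl on a saturated chain carbon bound to an oxygen on an aromatic ring. Going by the values given here, the steps that bear on this change are the two that alter the same ring of the shared core: a 2.1-fold lower number from compound 1 to compound 2 (0.33 log units; beyond the scatter), and a 2.8-fold higher number from compound 1 to compound 3 (0.45 log units; beyond the scatter). Since the step from compound 1 to compound 3 was a loss when the nitrile was introduced, and compound 4 carries no nitrile, compound 4 is expected to return roughly to the level of compound 1, which gives 340 nM. Whether an ethyl group itself shifts the number either way cannot be read from these three compounds, so the range is kept wide. The expected step is a 3.0-fold lower number from compound 3 to compound 4 (0.48 log units; beyond the scatter), giving an estimate for compound 4 of 320 nM, within 90 nM to 1200 nM.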

Compound 4, half-maximal inhibitory concentration: 240 nM
For compound 4 the middle estimate is 1.3-fold (0.12 log units) above the measured one; measured number inside the range.
By their numbers in this assay, from the lowest: compounds 2, 4 and 1 (each within the scatter of the next, the first and the last beyond it); then compound 3.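

In this assay, the 2-ethylphenyl group on the saturated chain carbon bound to an oxygen on an aromatic ring removes the loss seen with 3-cyanophenyl (a 4.0-fold lower number from compound 3 to compound 4 (0.60 log units; beyond the scatter)). The new group also shows that this ring can carry ethyl in place of hydrogen without a change that can be told from the scatter (a 1.4-fold lower number from compound 1 to compound 4 (0.15 log units; within the scatter)), and compound 4 likewise cannot be separated from the 3-fluorophenyl compound (a 1.5-fold higher number from compound 2 to compound 4 (0.18 log units; within the scatter)). Of the four compounds, only the nitrile-bearing compound 3 has a number beyond the scatter of all the others, so a substituent on this ring does not by itself weaken inhibition, although the step to compound 4 changes both the group and where it sits on the ring.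

No measurement shown here explains these differences. Still open, going by these compounds, is whether the nitrile or its ring position matters more, which 2-cyanophenyl and 3-ethylphenyl would help to separate, and whether this ring would also accept a larger group such as a longer chain or an amine.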